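The compounds below may be only part of what the source reports. "The series", "measured", "known", "first", "only" and "open" are said of these compounds alone.

Compound 1 `Cc1ccc(Nc2nc(SCc3cn(CC(=O)NC(=O)Nc4ccccn4)nn3)nc(-c3ccc(C(C)C)cc3)c2C#N)cc1`: in a functional assay on MGC-803 cells (Homo sapiens) for inhibition, read by MTT assay, with a stated time of 72 h (on this read-out lower numbers stand for stronger inhibition and higher numbers for weaker inhibition), compound 1 gives 3360 nM.
Compound 2 `COc1ccccc1Nc1nc(SCc2cn(CC(=O)NC(=O)Nc3ccccn3)nn2)nc(-c2ccc(C(C)C)cc2)c1C#N`: in this assay compound 2 gives > 64000 nM, which is a limit of the assay and not a measured number.

Compound 2 therefore sits at the limit of > 64000 nM in this assay, at which 1 of the 2 values shown sits, the weakest end of the numbers shown. The change to compound 3 `CC(C)c1ccc(-c2nc(SCc3cn(CC(=O)NC(=O)Nc4ccccn4)nn3)nc(Nc3ccccc3O)c2C#N)cc1` is hydrogen in place of methyl on an oxygen on an aromatic ring. Going by the values given here, the only measured step, an at least 19-fold higher number from compound 1 to compound 2 (1.27 log units; beyond the scatter), concerns the group on a nitrogen on an aromatic ring and does not bear on a methyl leaving an oxygen, so no measured comparison guides this change. In this assay compound 3 is expected near 50000 nM, between 10000 nM and 128000 nM, an expected at least 1.2-fold lower number from compound 2 to compound 3 (0.10 log units; that floor lies within the scatter).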

Compound 3, half-maximal inhibitory concentration: 16400 nM
Compound 3: the middle estimate sits 3.0-fold (0.48 log units) above what was measured; the range from low to high includes it.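

In this assay, hydrogen in place of methyl on this oxygen gives an at least 3.9-fold lower number from compound 2 to compound 3 (0.59 log units; beyond the scatter), so removing one methyl is enough to move the read-out at this position. Compound 2 gives > 64000 nM, which is a limit of the assay and not a number. The 2-hydroxyphenyl group still does not match 4-methylphenyl on the nitrogen, with a 4.9-fold higher number from compound 1 to compound 3 (0.69 log units; beyond the scatter).

From the compounds shown here alone, what an amine in place of the hydroxy would do stays open, as does the effect of a longer chain, such as ethyl, on this oxygen.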